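A few compounds are considered here, and "the series" means these few. Any claim that something is new, unique, unknown or untested is made for them only; others in the source may bear on it.

Of the compounds shown here, three built on a shared core have been tested in an assay on CHO-TREX cells for antagonist activity at transient receptor potential cation channel subfamily A member 1 (Homo sapiens), read by FLIPR and calcium flux, with a stated time of 10 min; a lower number here means a stronger inhibitor, a higher number a weaker inhibitor. Compound 1 `Fc1cccc(-c2ccc3[nH]ncc3c2)c1C(F)(F)F` gives 8900 nM. Compound 2 `Fc1cc2[nH]ncc2cc1-c1ccccc1C(F)(F)F` gives 48 nM, and compound 3 `CCc1cc2[nH]ncc2cc1-c1ccccc1C(F)(F)F` gives 50 nM. On these numbers compound 3 stands close beside compound 2, the two being indistinguishable within the scatter, while both lie a long way from the much higher number of compound 1. For the measured compounds named here, the one single-point step among the measured compounds is a 1.0-fold higher number from compound 2 to compound 3 (0.02 log units; within the scatter), an exchange at the carbon that carries the ethyl in compound 3.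

Compound 4 `FC(F)(F)c1ccccc1-c1cc2cn[nH]c2cc1C1CC1` differs from compound 3 at that same carbon: cyclopropyl in place of ethyl on an aromatic carbon. Going by the values given here, the only measured step that bears on this position, from compound 2 to compound 3, stayed within the scatter, and nothing measured speaks to a ring in place of the chain. The expectation is therefore a step of no change at the digits printed from compound 3 to compound 4 (within the scatter) in this assay, none beyond the scatter in either direction. Compound 4 is expected to give about 50 nM, within a range from 18 nM to 140 nM.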

Compound 4, half-maximal inhibitory concentration: 61 nM
The estimate for compound 4 lay 1.2-fold (0.09 log units) below the measured number; measured number inside the range.
By their numbers in this assay, from the lowest: compounds 2, 3 and 4 (each within the scatter of the next); then compound 1.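

In this assay, the aromatic carbon that carries the ethyl in compound 3 also tolerates a ring, since the step to cyclopropyl lies within the scatter (a 1.2-fold higher number from compound 3 to compound 4 (0.09 log units; within the scatter)). The same holds against the fluoro of compound 2 (a 1.3-fold higher number from compound 2 to compound 4 (0.10 log units; within the scatter)), so fluoro, ethyl and cyclopropyl at this carbon cannot be told apart here, although the three groups differ in heavy atoms and only cyclopropyl has a ring. Nothing available explains why these exchanges leave the number within the scatter.

On these data alone, whether a longer chain such as butyl, a larger ring such as cyclohexyl, or an amine or a carboxylic acid at this carbon would stay within the scatter remains open. The compounds shown also do not tell how large a group this position can carry before the number moves beyond the scatter.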